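Cytotoxicity notes on a thieno-pyrimidine ether series

The compounds below may be only part of what the source reports. "The series", "measured", "known", "first", "only" and "open" are said of these compounds alone.

Compound 1 `N#C/C=C/c1cc(F)c(Oc2nc(Nc3ccc(C#N)c(F)c3)nc3ccsc23)c(F)c1` gives 96000 nM in a toxicity assay on MT4 cells (Homo sapiens) for cytotoxicity, read by MTT assay, with a stated time of 5 days; on this read-out lower numbers stand for higher toxicity in this test and higher numbers for lower toxicity in this test. Compound 2 `N#C/C=C/c1cc(F)c(Oc2nc(Nc3ccc(C#N)nc3)nc3ccsc23)c(F)c1` carries the change (6-cyanopyridin-3-yl in place of 4-cyano-3-fluorophenyl on a nitrogen on an aromatic ring); in this assay compound 2 gives 47500 nM, so the step of a 2.0-fold lower number from compound 1 to compound 2 (0.31 log units; beyond the scatter). Compound 3 `Cc1cc(-c2ccc(C#N)cc2)cc(C)c1Oc1nc(Nc2ccc(C#N)c(F)c2)nc2ccsc12` rests on a different core; the difference between the two cores is not broken down here. In this assay compound 3 gives 71500 nM, which sits within the scatter of both compound 1 and compound 2. Compound 4 `Cc1cc(-c2ccc(C#N)cc2)cc(C)c1Oc1nc(Nc2ccc(C#N)nc2)nc2ccsc12` is not yet measured and carries the same change as that from compound 1 to compound 2, namely (6-cyanopyridin-3-yl in place of 4-cyano-3-fluorophenyl on a nitrogen on an aromatic ring). Because the earlier step gave a 2.0-fold lower number from compound 1 to compound 2 (0.31 log units; beyond the scatter) on the other core, the step from compound 3 to compound 4 is expected to be about a 2.0-fold lower number from compound 3 to compound 4 (0.30 log units; within the scatter), with wide uncertainty as it rests on a single pair. Compound 4 is thus estimated at 36000 nM, between 18000 nM and 72000 nM.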

Compound 4, half-maximal cytotoxic concentration: 214000 nM
Compound 4: middle estimate off by 5.9-fold (0.77 log units), on the low side; the measured number lies above the stated range.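

The new step is a 3.0-fold higher number from compound 3 to compound 4 (0.48 log units; beyond the scatter), so in this assay 6-cyanopyridin-3-yl in place of 4-cyano-3-fluorophenyl moves the number the opposite way on the core of compound 3. The result of this change therefore does not carry over between these two cores, and the two steps differ: the same change on two cores in this assay, a 2.0-fold lower number (0.31 log units; beyond the scatter) from compound 1 to compound 2 and a 3.0-fold higher number (0.48 log units; beyond the scatter) from compound 3 to compound 4, 6.0-fold (0.78 log units) apart, beyond the scatter of two such steps

This rests on a single pair per core and does not show why the cores differ or how the change would behave on a further core.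

Still open, on these data alone, is whether the same reversal appears with another group on that nitrogen, such as a carboxylic acid or a morpholine. Also open, as far as these compounds go, is which part of the difference between the two cores goes with it.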